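Replacing the oxan-4-yl group of compound 1 with isobutyl

The compounds below may be only part of what the source reports. "The series", "measured", "known", "first", "only" and "open" are said of these compounds alone.

Compound 1 `O=C(O)c1ccccc1-c1ccc(CCc2ncc(CC3CCOCC3)[nH]2)cc1` is the reference of this small set. Among the measured compounds shown here, in an in vitro functional assay on cells for agonist activity at Bombesin receptor subtype-3 (Homo sapiens), read by luminescence and calcium flux (on this read-out higher numbers stand for an effect only at larger amounts of compound and lower numbers for an effect already at smaller amounts), compound 1 gives 338 nM, the lowest number among the three measured members. Compound 2 `COc1ccc(Cc2cnc(CCc3ccc(-c4ccccc4C(=O)O)cc3)[nH]2)cc1` gives 5360 nM and compound 3 `O=C(O)c1ccccc1-c1ccc(CCc2ncc(Cc3ccc(Cl)cc3)[nH]2)cc1` gives 2290 nM; the steps are a 16-fold higher number from compound 1 to compound 2 (1.20 log units; beyond the scatter) and a 6.8-fold higher number from compound 1 to compound 3 (0.83 log units; beyond the scatter), while between the two aryl-bearing members the step is a 2.3-fold lower number from compound 2 to compound 3 (0.37 log units; beyond the scatter).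

Compound 4 `CC(C)CCc1cnc(CCc2ccc(-c3ccccc3C(=O)O)cc2)[nH]1` has not been measured. It differs from compound 1 in one place: isobutyl in place of oxan-4-yl on a saturated chain carbon bound to an aromatic carbon.

Both measured steps from compound 1 exchange the oxan-4-yl group for a substituted phenyl group on the same saturated chain carbon, and both raise the number well beyond the scatter, by a modest to large amount. The change to compound 4 also removes the oxan-4-yl group, but what enters is an isobutyl chain rather than a ring, so the measured steps bear on it only in part. Some increase in the number is therefore expected, smaller than for the aryl replacements, with the step estimated as a 3.0-fold higher number from compound 1 to compound 4 (0.47 log units; beyond the scatter). For compound 4 the expected value is 1000 nM, within a range from 300 nM to 3500 nM.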

Compound 4, half-maximal effective concentration: 119 nM
Estimate against measurement, compound 4: 8.4-fold (0.92 log units) above; measured number below the stated range.
By their numbers in this assay, from the lowest: compound 4; then compound 1; then compound 3; then compound 2.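

Among the compounds shown here, the step of a 2.8-fold lower number from compound 1 to compound 4 (0.45 log units; beyond the scatter) in this assay is the first change at this position that lowers the number, so the oxan-4-yl group of compound 1 does not mark the low end here, and leaving the ring out does not cost activity in this read-out. The aryl-bearing members lie much further off, with a 19-fold lower number from compound 3 to compound 4 (1.28 log units; beyond the scatter) and a 45-fold lower number from compound 2 to compound 4 (1.65 log units; beyond the scatter) marking large gaps, and in this set of four all three groups carrying a ring give higher numbers than the open isobutyl chain, which has no ring and no hydrogen-bond acceptor. No measurement at hand accounts for this order.

With a single open chain in the set, the loss of the ring and the loss of the ring oxygen remain unseparated, and a cyclohexyl group on the same saturated chain carbon would tell the two apart. How far the trend runs in open chains also stays undecided, and a longer chain or a chain ending in an amine in place of isobutyl would test whether the number keeps falling or turns back up.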